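Moving a Methoxy Group on the Sulfonyl-Bound Ring

This account rests on a few compounds, and the source may have more. Where it says the series, first, only, none or still open, it means among the compounds named here.

Compound 1 `COc1cc2c(Oc3ccc(NC(=O)c4cn(-c5ccccc5OC)cn4)cc3F)ccnc2cc1OCCCN1CCN(C)CC1` gives 70 nM
Compound 2 `COc1cc2c(Oc3ccc(NC(=O)/C=C/S(=O)(=O)c4ccccc4F)cc3F)ccnc2cc1OCCCN1CCN(C)CC1` gives 150 nM
Compound 3 `COc1cc2c(Oc3ccc(NC(=O)/C=C/S(=O)(=O)c4ccccc4OC)cc3F)ccnc2cc1OCCCN1CCN(C)CC1` gives 320 nM

All three compounds were tested in a functional assay on A549 cells (Homo sapiens) for cytotoxicity, read by MTT assay, with a stated time of 72 h; on this read-out higher numbers stand for weaker inhibition and lower numbers for stronger inhibition. Among them compound 3 stands with the highest number, 320 nM; compound 2 gives 150 nM and compound 1 gives 70 nM. Among the compounds with values here, the only single-point step among the measured compounds is a 2.1-fold higher number from compound 2 to compound 3 (0.33 log units; beyond the scatter), which exchanged one group for a different one on the ring attached to the sulfonyl sulfur.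

Compound 4 `COc1ccc(S(=O)(=O)/C=C/C(=O)Nc2ccc(Oc3ccnc4cc(OCCCN5CCN(C)CC5)c(OC)cc34)c(F)c2)cc1` differs from compound 3 in one place: 4-methoxyphenyl in place of 2-methoxyphenyl on a sulfonyl sulfur. This is not an exchange of one group for another; the same methoxy-bearing ring simply appears in its other arrangement. Within the data shown here, no measured pair compares two rings that carry the same group at different places, so the step from compound 2 to compound 3 bears only loosely on this change, and the data give no direction for it. The expectation is therefore a step of no change at the digits printed from compound 3 to compound 4 (within the scatter) in this assay, not beyond the scatter. Compound 4 is estimated at 320 nM, with a range from 110 nM to 950 nM.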

Compound 4, half-maximal inhibitory concentration: 1870 nM
Compound 4: the middle estimate sits 5.8-fold (0.77 log units) below what was measured; the whole stated range lies below it.
By their numbers in this assay, from the lowest: compound 1; then compound 2; then compound 3; then compound 4.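

In this assay, the same atoms on the sulfonyl sulfur give a clearly different result depending on how they are arranged: 4-methoxyphenyl in place of 2-methoxyphenyl brings a 5.8-fold higher number from compound 3 to compound 4 (0.77 log units; beyond the scatter). This shows that the place of the methoxy group on this ring matters, and that the change is larger than the exchange of fluoro for methoxy within the 2-substituted rings, which gave a 2.1-fold higher number from compound 2 to compound 3 (0.33 log units; beyond the scatter), while 4-methoxyphenyl in place of 2-fluorophenyl gives a 12-fold higher number from compound 2 to compound 4 (1.10 log units; beyond the scatter). Nothing measured here explains why the arrangement of the ring has this effect.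

The compounds shown leave open whether a fluoro group on this ring would respond to the same move as the methoxy group does, since only one ring type appears in both arrangements. They also leave open how the number would shift if the methoxy group gave way to an amine, a carboxylic acid or a longer chain such as ethoxy, and whether such groups would follow the same dependence on place.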